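This account rests on a few compounds, and the source may have more. Where it says the series, first, only, none or still open, it means among the compounds named here.

In a functional assay on Huh-5-2 cells (Homo sapiens) for cytotoxicity, read by microscopy (a higher number here means that more compound is tolerated, a lower number that less compound is tolerated), three compounds with a shared core have been measured so far. Compound 1 `CC(=O)OC[C@H]1O[C@@H](n2c(SCc3cc4cc(Br)ccc4oc3=O)nc3cncnc32)[C@H](OC(C)=O)[C@@H]1OC(C)=O` gives 6700 nM, compound 2 `CC(=O)OC[C@H]1O[C@@H](n2c(SCc3cc4cc(Br)cc(Br)c4oc3=O)nc3cncnc32)[C@H](OC(C)=O)[C@@H]1OC(C)=O` gives 6000 nM, and compound 3 `CC(=O)OC[C@H]1O[C@@H](n2c(SCc3cc4ccccc4oc3=O)nc3cncnc32)[C@H](O)[C@@H]1O` gives 8700 nM. The value of compound 3 lies within the usual scatter of the other two, so these three numbers cannot be ranked.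

Compound 4 `CC(=O)OC[C@H]1O[C@@H](n2c(SCc3cc4cc(C)ccc4oc3=O)nc3cncnc32)[C@H](O)[C@@H]1O` differs from compound 3 in one place: methyl in place of hydrogen on an aromatic carbon. In words, this is methyl in place of hydrogen on an aromatic carbon. Among the compounds with values here, only one measured step bears on this, and it is also a small group placed on an aromatic carbon, namely bromo in place of hydrogen: a 1.1-fold lower number from compound 1 to compound 2 (0.05 log units; within the scatter). That step stays within the scatter. It involves a different group, so it is only a loose guide, but it gives no reason to look for a large shift. No change beyond the scatter is expected, and the estimated step is a 1.2-fold lower number from compound 3 to compound 4 (0.06 log units; within the scatter). For compound 4 the estimated value is 7500 nM, with an expected range from 4000 nM to 14000 nM.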

Compound 4, half-maximal cytotoxic concentration: 16000 nM
Estimate against measurement, compound 4: 2.1-fold (0.33 log units) below, outside the stated range (above it).
By their numbers in this assay, from the lowest: compounds 2, 1, 3 and 4 (each within the scatter of the next, the first and the last beyond it).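

In this assay, within the data shown here, the replacement of hydrogen by methyl gives a 1.8-fold higher number from compound 3 to compound 4 (0.26 log units; within the scatter) and so provides the first direct reading for methyl on this aromatic carbon, which is meta to a fused ring and para to a fused ring. Taken alone, this step does not show that methyl here changes how much compound the cells tolerate, even though compound 4 and compound 2 lie beyond the scatter of each other at the two ends of the series. No measurement is available that bears on the size of this step.

Going by these compounds, whether an amine, a carboxylic acid or a longer chain on this carbon would move the number beyond the scatter remains open. On these data alone, it is also open whether methyl here would give a similar step on a compound with all three acetyl esters, such as compound 1.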